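The source may hold more compounds than are shown below. What is called first, only, known or untested is meant among the compounds shown, and "the series" means these compounds.

Measured compounds in a functional assay on HepG2 cells (Homo sapiens) for antiproliferative activity, read by MTT assay, with a stated time of 48 h; on this read-out higher numbers stand for weaker inhibition and lower numbers for stronger inhibition:

- compound 1 `Cc1ccc(Cl)cc1-n1nncc1CN1C(=O)C2(C(C#N)=C(N)Oc3c2c2nc4ccccc4nc2c2ccccc32)c2ccccc21`: > 50000 nM, a limit of this assay
- compound 2 `N#CC1=C(N)Oc2c(c3nc4ccccc4nc3c3ccccc23)C12C(=O)N(Cc1cnnn1-c1ccc(F)c(Cl)c1)c1ccccc12`: > 50000 nM, a limit of this assay
- compound 3 `Cc1ccc(Cl)cc1-n1nncc1CN1C(=O)C2(C(C#N)=C(N)Oc3c(N)cc4nc5ccccc5nc4c32)c2ccccc21`: 17300 nM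

Compound 1 reaches only a limit, > 50000 nM. Compound 2 likewise reaches only a limit, > 50000 nM. The change between them is 3-chloro-4-fluorophenyl in place of 5-chloro-2-methylphenyl on an aromatic nitrogen, and the step that the two limits leave unreadable from compound 1 to compound 2 cannot be sized because of the limit of > 50000 nM in this assay, at which 2 of the 3 values shown sit. Going by the values given here, compound 3 gives the single number of the set, 17300 nM. How the core of compound 3 differs from the core of compound 1 is not broken down here.

Compound 4 `N#CC1=C(N)Oc2c(N)cc3nc4ccccc4nc3c2C12C(=O)N(Cc1cnnn1-c1ccc(F)c(Cl)c1)c1ccccc12` is the counterpart of compound 3 after (3-chloro-4-fluorophenyl in place of 5-chloro-2-methylphenyl on an aromatic nitrogen); the place is described in the same words as for the pair compound 1 to compound 2, so this is the same change made on the core of compound 3. Among the compounds with values here, the one earlier instance of this change gives no readable size, so no direction is carried over from it. The step of a 1.2-fold higher number from compound 3 to compound 4 (0.06 log units; within the scatter) is therefore expected to be small, with wide uncertainty, resting on compound 3 at 17300 nM. Compound 4 is expected to give about 20000 nM in this assay, with a likely range from 6000 nM to 50000 nM, and a fair chance that only a limit is reported.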

Compound 4, half-maximal inhibitory concentration: > 50000 nM
Compound 4 gave a limit, no number (the forecaster's own chance of this, stated with the estimate: 35%); middle value at least 2.5-fold (0.39 log units) away from the limit.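

In this assay, 3-chloro-4-fluorophenyl in place of 5-chloro-2-methylphenyl on the aromatic nitrogen gives an at least 2.8-fold higher number from compound 3 to compound 4 (0.46 log units; beyond the scatter), so on this core the change costs activity beyond the scatter, and the size printed is only a lower bound. The same change on the core of compound 1 cannot be read, which leaves one readable instance and no comparison of size between the two cores. Neither the full size of the step nor whether it carries from one core to another can be settled, for one reason: the limit of > 50000 nM in this assay, at which 3 of the 4 values shown sit.

The two aryl groups differ in both the methyl and the fluoro substituent, so the compounds shown do not separate the loss of the one from the gain of the other. Also open, on these data alone, is whether an aryl group carrying a carboxylic acid or a dimethylamino group on the same nitrogen would give a readable number on either core.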